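Exchanging the (Phenoxycarbonyl)amino Group for Nitro

The compounds below may be only part of what the source reports. "The series", "measured", "known", "first", "only" and "open" are said of these compounds alone.

compound 1 `COCC(=O)Nc1ccc2c(cnn2CC(=O)COc2ccc(Oc3ccccc3)cc2)c1` — 6300 nM
compound 2 `O=C(COc1ccc(Oc2ccccc2)cc1)Cn1ncc2cc(NC(=O)CO)ccc21` — 5400 nM
compound 3 `O=C(COc1ccc(Oc2ccccc2)cc1)Cn1ncc2cc(NC(=O)Oc3ccccc3)ccc21` — 2100 nM

In an assay on microsomes from brain for inhibition of Fatty-acid amide hydrolase 1 (Rattus norvegicus), read by fluorescence and HPLC, with a stated time of 45 min (on this read-out lower numbers stand for stronger inhibition and higher numbers for weaker inhibition), compound 3 gives the lowest number of the three measured compounds, and both a 3.0-fold lower number from compound 1 to compound 3 (0.48 log units; beyond the scatter) and a 2.6-fold lower number from compound 2 to compound 3 (0.41 log units; beyond the scatter) lie beyond the scatter, so compound 3 stands apart from compound 1 and compound 2. Compound 4 `O=C(COc1ccc(Oc2ccccc2)cc1)Cn1ncc2cc([N+](=O)[O-])ccc21` differs from compound 3 by nitro in place of (phenoxycarbonyl)amino on an aromatic carbon, a much smaller group without a hydrogen-bond donor replacing a larger one. Among the measured compounds shown here, no measured step removes the whole (phenoxycarbonyl)amino group; the steps that bear on it are a 3.0-fold lower number from compound 1 to compound 3 (0.48 log units; beyond the scatter) and a 2.6-fold lower number from compound 2 to compound 3 (0.41 log units; beyond the scatter), showing a modest gain from the phenoxy on the carbonyl carbon, while a 1.2-fold lower number from compound 1 to compound 2 (0.07 log units; within the scatter) shows little difference between smaller groups there. Compound 4 is therefore expected to give a higher number than compound 3, a 2.9-fold higher number from compound 3 to compound 4 (0.46 log units; beyond the scatter). Compound 4 is estimated at 6000 nM, in a range from 1500 nM to 25000 nM.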

Compound 4, half-maximal inhibitory concentration: 550 nM
Compound 4: middle estimate off by 11-fold (1.04 log units), on the high side; measured number outside the range, below it.
By their numbers in this assay, from the lowest: compound 4; then compound 3; then compounds 2 and 1 (each within the scatter of the next).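

At this aromatic carbon, a low number does not depend on the (phenoxycarbonyl)amino group with its aromatic ring and hydrogen-bond donor: nitro, with neither, gives a 3.8-fold lower number from compound 3 to compound 4 (0.58 log units; beyond the scatter). The steps from the two other amides are larger, a 9.8-fold lower number from compound 2 to compound 4 (0.99 log units; beyond the scatter) and an 11-fold lower number from compound 1 to compound 4 (1.06 log units; beyond the scatter), so the earlier gain from phenoxy on the carbonyl carbon does not mean that a larger group here gives a lower number. Nothing available explains this drop. On these data alone, whether an amine, a nitrile or a carboxylic acid on this carbon would match nitro remains open.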